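This account rests on a few compounds, and the source may have more. Where it says the series, first, only, none or still open, it means among the compounds named here.

Measured so far:
- compound 1, `CN1CCN(c2ccc(Nc3ncc4nc(Nc5ccc(F)cc5)n([C@H]5CCCN(C(=O)CO)C5)c4n3)cc2)CC1`: 1.8 nM
- compound 2, `CN1CCN(c2ccc(Nc3ncc4nc(Nc5ccc(F)cc5)n([C@H]5CCCC(NC(=O)OC(C)(C)C)C5)c4n3)cc2)CC1`: 120 nM
- compound 3, `CNC(=O)CN1CC[C@H](n2c(Nc3ccccc3)nc3cnc(Nc4ccc(N5CCN(C)CC5)cc4)nc32)C1`: 170 nM

All three were tested in a functional assay on HCC827 cells (Homo sapiens) for antiproliferative activity, read by MTT assay, with a stated time of 72 h; a lower number here means a stronger inhibitor, a higher number a weaker inhibitor. Compound 1 has the lowest number of the three, and its gap to the nearest of them, compound 2, is well beyond the scatter of repeated measurements, as is its gap to compound 3, which stands furthest away. Compound 1 is therefore the most potent of the set shown.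

The unmeasured compound 4, `CCOC(=O)CN1CC[C@H](n2c(Nc3ccc(F)cc3)nc3cnc(Nc4ccc(N5CCN(C)CC5)cc4)nc32)C1`, is built from compound 1 by a single exchange on an aromatic nitrogen of the shared core: 1-((ethoxycarbonyl)methyl)pyrrolidin-3-yl in place of 1-((hydroxymethyl)carbonyl)piperidin-3-yl on an aromatic nitrogen. Both the ring attached there and the group on that ring's nitrogen are changed, so the step is not a small one in structural terms. The other two measured compounds show that departures from the substituent of compound 1 at this position have gone along with much higher numbers. The step from compound 1 to compound 4 in this assay is expected to be an increase of roughly a 22-fold higher number from compound 1 to compound 4 (1.35 log units; beyond the scatter), beyond the scatter. Compound 4 is estimated at 40 nM, in the range 8 nM to 200 nM.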

Compound 4, half-maximal inhibitory concentration: 1810 nM
Compound 4: middle estimate off by 45-fold (1.66 log units), on the low side, and the stated range ends below it.
By their numbers in this assay, from the lowest: compound 1; then compounds 2 and 3 (each within the scatter of the next); then compound 4.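

In this assay, within the data shown here, the exchange of 1-((hydroxymethyl)carbonyl)piperidin-3-yl for 1-((ethoxycarbonyl)methyl)pyrrolidin-3-yl gives a 1000-fold higher number from compound 1 to compound 4 (3.00 log units; beyond the scatter) and is the first step here that can be read at a single place, with the (4-fluorophenyl)amino group and the rest of the molecule unchanged. It shows that potency in these cells can depend very strongly on the group on this aromatic nitrogen. The exchange alters the ring size, the group on the ring nitrogen and the count of hydrogen-bond donors all at once, and nothing measured here explains the loss.

Still open is which of these changes matters most, since neither the piperidin-3-yl ring with the ethoxycarbonylmethyl group nor the pyrrolidin-3-yl ring with the hydroxyacetyl group appears among these compounds. Also open, on these data alone, is how a carboxylic acid in place of the ethyl ester would compare.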